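This account rests on a few compounds, and the source may have more. Where it says the series, first, only, none or still open, it means among the compounds named here.

Compound 2 `CC1CCN(C2CCN(S(=O)(=O)c3cccc(N)c3)CC2)CC1` gives the higher of the two plain numbers shown in a functional assay on DLD-1 cells (Homo sapiens) for antiproliferative activity, read by CellTiter-Glo, with a stated time of 72 h (a lower number here means a stronger inhibitor, a higher number a weaker inhibitor), 3400 nM. Compound 3 `CC1CCN(C2CCN(S(=O)(=O)c3cnc(Cl)s3)CC2)CC1` gives 1800 nM in this assay, and a 1.9-fold lower number from compound 2 to compound 3 (0.28 log units; within the scatter). Compound 1 `CC1CCN(C2CCN(S(=O)(=O)c3cccnc3Cl)CC2)CC1` reached only the limit of this assay, > 5000 nM. The shifts an at least 1.4-fold lower number from compound 1 to compound 2 (0.16 log units; that floor lies within the scatter) and an at least 2.7-fold lower number from compound 1 to compound 3 (0.44 log units; beyond the scatter) show that swapping the aromatic group on the sulfonyl sulfur moves the number, but only modestly. Compound 4 `CC1CCN(C2CCN(S(=O)(=O)c3cccc(-c4ccccc4F)c3)CC2)CC1` is not yet measured; it differs from compound 2 in that (2-fluorophenyl in place of amino on an aromatic carbon). For the measured compounds named here, no measured step exchanges an amino for a 2-fluorophenyl, so the three measured compounds offer only a general sense of spread. The expected step in this assay is therefore small, a 1.7-fold lower number from compound 2 to compound 4 (0.23 log units; within the scatter). Compound 4 is estimated at 2000 nM, within 400 nM to 8000 nM.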

Compound 4, half-maximal inhibitory concentration: 10 nM
For compound 4 the middle estimate is 200-fold (2.30 log units) above the measured one; the whole stated range lies above it.
By their numbers in this assay, from the lowest: compound 4; then compounds 3 and 2 (each within the scatter of the next). At a limit, above all of these: compound 1.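

Swapping amino for 2-fluorophenyl on this aromatic carbon gives a 340-fold lower number from compound 2 to compound 4 (2.53 log units; beyond the scatter) in this assay. The earlier compounds shown here changed the whole aromatic group on the sulfonyl sulfur, and compounds 2 and 3 stayed within the scatter of each other; this step shows that a single group at this place, meta to a large group, can change the number far more. Nothing shown here explains the size of this step.

Still open, going by these compounds, is whether the step depends on the added ring, on its fluorine, or simply on the loss of the amino. A plain phenyl, a methyl or a hydrogen at this place would help separate these.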